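Hydroxy for amino in an ortho-substituted benzohydrazide

The source may report more compounds than this note shows. Statements on the series, on what has been measured and on what is new or still open speak of the compounds shown alone.

Compound 1, `CC(C)NNC(=O)c1ccccc1N`, gives 0.9 in a physicochemical assay for lipophilicity, measured as octanol-water partition (a lower number here means a more polar compound, a higher number a more lipophilic compound), the highest of the three numbers measured. Compound 3, `Cc1ncsc1C(=O)NNC(C)C`, gives 0.44 in this assay, and compound 2, `Cc1ncc(C(=O)NNC(C)C)c(C)n1`, gives -0.4 in this assay; compound 1 stands above both, and each gap lies beyond the scatter. Compound 4, `CC(C)NNC(=O)c1ccccc1O`, has not been measured. It differs from compound 1 in one place: hydroxy in place of amino on an aromatic carbon. For the measured compounds named here, no measured pair shows this exchange, so the expected step rests on the structures alone. An increase beyond the scatter is expected, a step of a number 0.50 log units higher from compound 1 to compound 4 (beyond the scatter) in this assay. Compound 4 is therefore estimated at 1.4, within a range from 0.9 to 1.9.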

Compound 4, partition coefficient: 1.46
Compound 4: the middle estimate sits 0.06 log units below what was measured, and the stated range covers the measured number.
By their numbers in this assay, from the lowest: compound 2; then compound 3; then compound 1; then compound 4.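

In this assay, the change from amino to hydroxy ortho to a group of 7 heavy atoms gives a number 0.56 log units higher from compound 1 to compound 4 (beyond the scatter) and so lies beyond the scatter. For the compounds shown here, this is the first step read at this position, and it appears although both groups have the same printed counts of heavy atoms, hydrogen-bond donors and acceptors. Nothing shown accounts for this step. The compounds shown leave open how a methoxy group or a carboxylic acid at this position would compare with the hydroxy of compound 4. They also leave open whether the same exchange gives a similar step at another place on the ring.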